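The source may report more compounds than this note shows. Statements on the series, on what has been measured and on what is new or still open speak of the compounds shown alone.

The account begins with a small set built on one shared core. Compound 1 is `O=S(=O)(c1ccc(O)c2ncccc12)C1CCCC1`; in an ADME assay on cells (Hepatocyte, Rattus norvegicus) for pharmacokinetics (a higher number here means faster removal of the compound, a lower number slower removal), compound 1 has no reported result, recorded as "not determined" (no result reported). Compound 2 is `O=S(=O)(c1ccc(F)cc1)c1cc(Cl)c(O)c2ncccc12`, and in this assay compound 2 gives 4 uL/min. Compound 3 is `O=S(=O)(c1cc(F)c(O)c2ncccc12)C1CCCC1`, and in this assay compound 3 gives 19 uL/min. Of the two numbers available, compound 3 carries the higher one, with compound 2 the lower, and the gap between them lies beyond the usual scatter of this kind of measurement. Among the measured compounds shown here, no step between directly comparable measured compounds is available.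

Compound 4 is `O=S(=O)(c1cc(Cl)c(O)c2ncccc12)C1CCCC1`. It differs from compound 3 by chloro in place of fluoro on an aromatic carbon. For the measured compounds named here, nothing among the measured compounds isolates this change, so the expectation rests on compound 3 alone. Going by the values given here, the step expected in this assay is estimated at a 1.1-fold lower number from compound 3 to compound 4 (0.05 log units; within the scatter), a change not beyond the scatter, because compound 3 gives 19 uL/min and no measured pair shows this exchange moving the number. Compound 4 is therefore expected to give 17 uL/min, estimated to lie between 7 uL/min and 40 uL/min.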

Compound 4, intrinsic clearance in a liver preparation (reported as CLH), per the amount of preparation that the assay uses: 18 uL/min
For compound 4 the middle estimate is 1.1-fold (0.02 log units) below the measured one; the measured number falls inside the stated range.
By their numbers in this assay, from the lowest: compound 2; then compounds 4 and 3 (each within the scatter of the next).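

The exchange of fluoro for chloro, on the aromatic carbon ortho to a hydroxy group, gives the only direct test of this position in this assay, and the step of a 1.1-fold lower number from compound 3 to compound 4 (0.02 log units; within the scatter) shows no difference between the two halogens there. With chloro held in place, cyclopentyl in place of 4-fluorophenyl on the sulfonyl sulfur gives a 4.5-fold higher number from compound 2 to compound 4 (0.65 log units; beyond the scatter), so of the two changes shown, only the one at the sulfonyl sulfur moves the number beyond the scatter. No accompanying measurement explains either step.

Going by these compounds, whether a methoxy group or a nitrile on the same aromatic carbon would also leave the number in this assay unmoved remains open. Compound 1, which carries hydrogen there, offers no comparison, its entry reading "not determined" (no result reported) in that assay's record.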